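Replacing penta-1,3-dien-1-yl with chloromethyl on a carbonyl carbon

This account rests on a few compounds, and the source may have more. Where it says the series, first, only, none or still open, it means among the compounds named here.

Of the compounds shown here, three sharing one core have been measured in a functional assay on HCT-116 cells (Homo sapiens) for inhibition, read by MTT assay, with a stated time of 48 h (on this read-out lower numbers stand for stronger inhibition and higher numbers for weaker inhibition), and they differ only in the group on a carbonyl carbon. Compound 1 `COCC(=O)N(Cc1ccc(OC)c(O)c1)c1cc(OC)c(OC)c(OC)c1` gives 230 nM, compound 2 `COc1ccc(CN(C(=O)C(C)Br)c2cc(OC)c(OC)c(OC)c2)cc1O` gives 140 nM, and compound 3 `C/C=C/C=C/C(=O)N(Cc1ccc(OC)c(O)c1)c1cc(OC)c(OC)c(OC)c1` gives 180 nM. Compound 3 is not separated from either of the others, as its two steps show: a 1.3-fold lower number from compound 1 to compound 3 (0.11 log units; within the scatter), and a 1.3-fold higher number from compound 2 to compound 3 (0.11 log units; within the scatter).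

The next compound, compound 4 `COc1ccc(CN(C(=O)CCl)c2cc(OC)c(OC)c(OC)c2)cc1O`, carries chloromethyl in place of penta-1,3-dien-1-yl on a carbonyl carbon. Within the data shown here, no measured compound yet holds chloromethyl itself. The closest comparison is compound 2, whose 1-bromoethyl group also bears a halogen atom. The remaining measured step at this place, a 1.6-fold lower number from compound 1 to compound 2 (0.22 log units; within the scatter), also stays inside the scatter, so none of the three groups tried here has moved the number beyond it. On these three compounds alone, no change beyond the scatter is expected, and the estimated step is a 1.1-fold lower number from compound 3 to compound 4 (0.04 log units; within the scatter). In this assay the estimate for compound 4 is 165 nM, with an expected range of 70 nM to 390 nM.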

Compound 4, half-maximal inhibitory concentration: 250 nM
Beside the measured number, compound 4's estimate is 1.5-fold (0.18 log units) below it; the measured number falls inside the stated range.
By their numbers in this assay, from the lowest: compounds 2, 3, 1 and 4 (each within the scatter of the next).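

With chloromethyl on a carbonyl carbon, the set at this place grows to four groups, and in this assay every new step stays within the scatter: against penta-1,3-dien-1-yl the change gives a 1.4-fold higher number from compound 3 to compound 4 (0.14 log units; within the scatter) and against 1-bromoethyl it gives a 1.8-fold higher number from compound 2 to compound 4 (0.25 log units; within the scatter) while chloro in place of methoxy on a saturated chain carbon bound to a carbonyl carbon gives a 1.1-fold higher number from compound 1 to compound 4 (0.04 log units; within the scatter) and so adds the closest pair of the set. The result extends what the first three compounds showed to a much smaller group, since going from 5 heavy atoms and 2 double bonds outside aromatic rings to 2 heavy atoms and no such double bond leaves compound 3 and compound 4 unseparated, and the two halogen-bearing groups in compound 2 and compound 4 are not separated either. No measured evidence bearing on these small steps is available.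

The compounds shown leave open whether any group at this place can move the number beyond the scatter, as all four remain inseparable. A plain methyl group, an amine, a carboxylic acid or a longer saturated chain on the carbonyl carbon would each put that question to a different kind of group.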